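Extending a Short Chain on Two Related Cores

A few compounds are considered here, and "the series" means these few. Any claim that something is new, unique, unknown or untested is made for them only; others in the source may bear on it.

Compound 1 `CCC(=O)Nc1cccc(S(=O)(=O)Oc2ccccc2C(C)C)c1` and compound 2 `CCCC(=O)Nc1cccc(S(=O)(=O)Oc2ccccc2C(C)C)c1` share one core and differ only at the end of an acyl chain. In a functional assay on HT-29 cells (Homo sapiens) for antiproliferative activity, read by sulforhodamine B assay, with a stated time of 48 h (a lower number here means a stronger inhibitor, a higher number a weaker inhibitor), compound 1 gives 22000 nM, and compound 2 gives 13000 nM. The change between them is methyl in place of hydrogen on a saturated chain carbon, two bonds along the chain from a carbonyl carbon, and it made a step of a 1.7-fold lower number from compound 1 to compound 2 (0.23 log units; within the scatter).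

Compound 3 `CCNC(=O)Nc1ccc(S(=O)(=O)Oc2ccccc2C(C)C)cc1` carries a different core; the difference between the two cores is not broken down here. In this assay compound 3 gives 1100 nM, a lower number than either compound 1 or compound 2.

Compound 4 `CCCNC(=O)Nc1ccc(S(=O)(=O)Oc2ccccc2C(C)C)cc1` differs from compound 3 by methyl in place of hydrogen on a saturated chain carbon, two bonds along the chain from an amide-type nitrogen. This is the same kind of change as that from compound 1 to compound 2, though the place differs: there the carbon sat two bonds along the chain from a carbonyl carbon, here two bonds along the chain from an amide-type nitrogen.

Because the earlier step was a 1.7-fold lower number from compound 1 to compound 2 (0.23 log units; within the scatter), the step from compound 3 to compound 4 is expected to be about as small, namely a 1.4-fold lower number from compound 3 to compound 4 (0.14 log units; within the scatter). Compound 4 is therefore estimated at 800 nM in this assay, within 350 nM to 2000 nM.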

Compound 4, half-maximal inhibitory concentration: 6300 nM
Estimate against measurement, compound 4: 7.9-fold (0.90 log units) below, and the stated range ends below it.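

Adding this methyl on the core of compound 3 did not behave as it did on the core of compound 1 in this assay: it gave a 5.7-fold higher number from compound 3 to compound 4 (0.76 log units; beyond the scatter). Set side by side, the two steps do not match, so in this series the size of the change on one core is no guide to its size on the other: the same change on two cores in this assay, a 1.7-fold lower number (0.23 log units; within the scatter) from compound 1 to compound 2 and a 5.7-fold higher number (0.76 log units; beyond the scatter) from compound 3 to compound 4, 9.7-fold (0.99 log units) apart, beyond the scatter of two such steps

This rests on one pair per core, and the two pairs also differ in the place of the change, two bonds along the chain from a carbonyl carbon in one and from an amide-type nitrogen in the other, so the mismatch is clear but the data do not show whether the core, that place or both lie behind it.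

On these data alone, whether a longer chain, such as butyl in place of the propyl of compound 4, would continue this rise remains open. Also open, as far as these compounds go, is how the ethylamino and propylamino chains would read on the core of compound 1, a comparison that could separate the core from the place of the change.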